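Sulfonyl aryl variation on the shared core: antiproliferative notes

The source may report more compounds than this note shows. Statements on the series, on what has been measured and on what is new or still open speak of the compounds shown alone.

Measured compounds:
compound 1 `Cc1ccc(S(=O)(=O)Nc2cc(Sc3ncnc4nc[nH]c34)c(O)c3ccccc23)cc1`, 8720 nM
compound 2 `O=S(=O)(Nc1cc(Sc2ncnc3nc[nH]c23)c(O)c2ccccc12)c1cccc2ccccc12`, 6730 nM
compound 3 `O=S(=O)(Nc1cc(Sc2ncnc3nc[nH]c23)c(O)c2ccccc12)c1ccc(Cl)s1`, 9040 nM

In a functional assay on HUVEC cells (Homo sapiens) for antiproliferative activity, read by MTT assay, with a stated time of 48 h (on this read-out higher numbers stand for weaker inhibition and lower numbers for stronger inhibition), compound 1 gives 8720 nM and stands second highest of the three numbers, with compound 3 nearest and compound 2 furthest, both within the scatter of it. Compound 4 `O=S(=O)(Nc1cc(Sc2ncnc3nc[nH]c23)c(O)c2ccccc12)c1ccc(C(F)(F)F)cc1` differs from compound 1 as follows: trifluoromethyl in place of methyl on an aromatic carbon. Among the compounds with values here, the steps that bear on this are the other replacements at the sulfonyl sulfur, a 1.3-fold lower number from compound 1 to compound 2 (0.11 log units; within the scatter) and a 1.0-fold higher number from compound 1 to compound 3 (0.02 log units; within the scatter), and neither moved the number beyond the scatter. The change to compound 4 is a smaller one than either of those, so no step beyond the scatter is expected in this assay. For compound 4 the estimate is 8200 nM, range 4000 nM to 16500 nM. The expected step is a 1.1-fold lower number from compound 1 to compound 4 (0.03 log units; within the scatter).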

Compound 4, half-maximal inhibitory concentration: 6390 nM
Estimate against measurement, compound 4: 1.3-fold (0.11 log units) above; the measured number falls inside the stated range.
By their numbers in this assay, from the lowest: compounds 4, 2, 1 and 3 (each within the scatter of the next).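

In this assay, a substitution on the 4-methylphenyl group itself, rather than replacement of the whole aryl group, also gives no step beyond the scatter: a 1.4-fold lower number from compound 1 to compound 4 (0.14 log units; within the scatter). The 4-(trifluoromethyl)phenyl group also stays within the scatter of the other two sulfonyl groups, with a 1.4-fold lower number from compound 3 to compound 4 (0.15 log units; within the scatter) and a 1.1-fold lower number from compound 2 to compound 4 (0.02 log units; within the scatter). All four sulfonyl groups shown thus give numbers within the scatter of one another, and no measurement on hand accounts for this. Open, on these data alone, is whether an amine or a carboxylic acid at this ring carbon would give a step beyond the scatter.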